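The source may hold more compounds than are shown below. What is called first, only, known or untested is meant among the compounds shown, and "the series" means these compounds.

Measured compounds in a functional assay on MCF7 cells (Homo sapiens) for cytotoxicity, read by MTT assay, with a stated time of 72 h; a higher number here means a weaker inhibitor, a lower number a stronger inhibitor:
compound 1 `N[C@H]1CC[C@H](Nc2c(C(=O)NCc3ccc(F)cc3)nc(Br)c3cccnc23)CC1` gives 2000 nM
compound 2 `COc1ccc(CNC(=O)c2nc(Br)c3cccnc3c2N[C@H]2CC[C@H](N)CC2)cc1` gives "not determined" (no result reported)
compound 3 `N[C@H]1CC[C@H](Nc2c(C(=O)NCc3ccc(Cl)cc3)nc(Br)c3cccnc23)CC1` gives "not determined" (no result reported)

Three compounds share one core and differ only in the group carried on the saturated chain carbon bound to the amide-type nitrogen. Of these, only compound 1 carries a number in this assay; compound 2 and compound 3 both stand without one, so compound 3 cannot be placed against compound 1 on the numbers shown, and no step between measured compounds is available.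

Compound 4 `N[C@H]1CC[C@H](Nc2c(C(=O)NCc3cccs3)nc(Br)c3cccnc23)CC1` is the next member of the set. Its change from compound 3 is thiophen-2-yl in place of 4-chlorophenyl on a saturated chain carbon bound to an amide-type nitrogen. Among the measured compounds shown here, with no measured step to lean on, the only anchor is the value of compound 1 in this assay, and a change of this kind among close relatives is expected to move the result by no more than the usual scatter, in either direction. Compound 4 is therefore expected to give about 2500 nM in this assay, with a range from 800 nM to 8000 nM.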

Compound 4, half-maximal inhibitory concentration: 7300 nM
Beside the measured number, compound 4's estimate is 2.9-fold (0.47 log units) below it, within the range that was stated.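

In this assay, among the compounds shown here, exchanging the 4-fluorophenyl group for thiophen-2-yl gives a 3.7-fold higher number from compound 1 to compound 4 (0.56 log units; beyond the scatter) and so provides the first readable step at this position. It shows that the cytotoxicity read-out is not indifferent to the aromatic ring held at this place, and that the five-membered sulfur-containing ring gives the weaker result of the pair. Steps involving compound 2 or compound 3 cannot be read, as neither has a number, and nothing measured explains the step shown.

The compounds shown leave open whether a 4-methoxyphenyl or 4-chlorophenyl group would differ from 4-fluorophenyl at this place. They also leave open how a cyclohexyl group, a pyridin-2-yl group or a longer chain such as 2-phenylethyl would read there.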